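A few compounds are considered here, and "the series" means these few. Any claim that something is new, unique, unknown or untested is made for them only; others in the source may bear on it.

Measured so far in an ADME assay on Vero cells (Chlorocebus sabaeus) for cytotoxicity, with a stated time of 72 h; a higher number here means a weaker inhibitor, a lower number a stronger inhibitor:
- compound 1 `CCOC(=O)c1cc(-c2cccc(OCc3cccc(C#N)c3)c2)on1`: > 128000 nM
- compound 2 `CCOC(=O)c1cc(-c2cccc(OCc3cccc(OC)c3)c2)on1`: > 128000 nM
- compound 3 `CCOC(=O)c1cc(-c2cccc(OCc3cccc(C)c3)c2)on1`: > 128000 nM

Each of these three values is a limit of the assay, not a number. Compound 1 gives only the limit > 128000 nM. Compound 2 likewise gives only the limit > 128000 nM. Compound 3 also gives only the limit > 128000 nM. Compound 3 therefore stands where the other two stand, at the limit of > 128000 nM in this assay, at which 3 of the 3 values shown sit, and no order among the three can be read.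

Compound 4 `CCOC(=O)c1cc(-c2cccc(OCc3cc(F)cc(F)c3)c2)on1` differs from compound 3 in one place: 3,5-difluorophenyl in place of 3-methylphenyl on a saturated chain carbon bound to an oxygen on an aromatic ring. The measured steps that bear on it are the exchanges at the same place among the three measured compounds: a step that the two limits leave unreadable from compound 1 to compound 2, a step that the two limits leave unreadable from compound 1 to compound 3 and a step that the two limits leave unreadable from compound 2 to compound 3. Each is unreadable in size because both of its ends sit at the limit of > 128000 nM in this assay, at which 3 of the 3 values shown sit. None of them shows that changing the group at this place moves the value at all.

In this assay, then, no step beyond the scatter is expected; the estimated step is a step that the limit leaves unreadable from compound 3 to compound 4. Compound 4 is expected to give about 150000 nM, with a range from 64000 nM to 350000 nM, and most probably only a limit again.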

Compound 4, half-maximal inhibitory concentration: > 128000 nM
Compound 4 was reported as a limit; the forecaster's own chance of this, stated with the estimate: 85%; the middle value does not contradict the limit.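

In this assay compound 4 gives only a limit, > 128000 nM. The steps to compound 4 from compound 1, compound 2 and compound 3 therefore cannot be read, because all four compounds sit at the same limit: the limit of > 128000 nM in this assay, at which 4 of the 4 values shown sit.

The compounds shown leave open whether changing the group at this place moves the value at all, and at what concentration any of the four would reach half-maximal inhibition.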